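From carbamoylmethyl to 4-methyl-1H-imidazol-2-yl

The source may report more compounds than this note shows. Statements on the series, on what has been measured and on what is new or still open speak of the compounds shown alone.

In an ADME assay on microsomes from liver (Rattus norvegicus) for metabolic stability (a lower number here means that the compound disappears faster, a higher number that the compound lasts longer), compound 3 (`CC(C)C(CC(N)=O)c1ccc(-c2ccc3cccc(F)c3c2)[nH]c1=O`) gives < 0.0667 h, which is a limit of the assay and not a number. Compound 1 (`CC(C)C(c1ccc(-c2ccc3cccc(F)c3c2)[nH]c1=O)N1CCCCS1(=O)=O`) gives 0.07 h, and compound 2 (`Cc1nc(C(c2ccc(-c3ccc4cccc(F)c4c3)[nH]c2=O)C(C)C)[nH]c1C`) gives 0.0733 h. Compound 4 (`Cc1c[nH]c(C(c2ccc(-c3ccc4cccc(F)c4c3)[nH]c2=O)C(C)C)n1`) carries 4-methyl-1H-imidazol-2-yl in place of the carbamoylmethyl of compound 3, on the same saturated chain carbon: 4-methyl-1H-imidazol-2-yl in place of carbamoylmethyl on a saturated chain carbon bound to an aromatic carbon and a saturated chain carbon. The closest measured step, an at least 1.0-fold lower number from compound 2 to compound 3 (0.04 log units; that floor lies within the scatter), exchanges 4,5-dimethyl-1H-imidazol-2-yl for carbamoylmethyl and stays within the scatter, as does a 1.0-fold higher number from compound 1 to compound 2 (0.02 log units; within the scatter). On that evidence, the expected step, an at least 1.0-fold higher number from compound 3 to compound 4 (0.02 log units; that floor lies within the scatter), stays within the scatter in this assay. Compound 4 is estimated at 0.07 h, with an expected range of 0.05 h to 0.11 h.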

Compound 4, half-life: < 0.0667 h
Compound 4: no number, only a limit (the forecaster's own chance of this, stated with the estimate: 40%); at least 1.0-fold (0.02 log units) between middle value and limit.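

In this assay compound 4 returns a limit of the assay and not a number, so 4-methyl-1H-imidazol-2-yl on this saturated chain carbon ends at the same limit as carbamoylmethyl: the limit of < 0.0667 h in this assay, at which 2 of the 4 values shown sit.

Hydrogen in place of methyl on an aromatic carbon gives an at least 1.0-fold lower number from compound 2 to compound 4 (0.04 log units; that floor lies within the scatter), and the exchange of the larger ring group gives an at least 1.0-fold lower number from compound 1 to compound 4 (0.02 log units; that floor lies within the scatter). The step between compound 3 and compound 4 cannot be read.

Going by these compounds, how far either compound lies past the limit stays open, as does whether an amine or a carboxylic acid at this place would give a longer half-life.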